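From 4-hydroxyphenyl to 2-chlorophenyl: a small expected step

The source may report more compounds than this note shows. Statements on the series, on what has been measured and on what is new or still open speak of the compounds shown alone.

Measured so far in a functional assay on PC-3 cells (Homo sapiens) for cytotoxicity, read by sulforhodamine B assay, with a stated time of 48 h; on this read-out higher numbers stand for weaker inhibition and lower numbers for stronger inhibition:
compound 1 `C[C@H]1CC[C@@H]2[C@@H](OC(=O)[C@]23CC(c2ccc(N(C)C)cc2)=NO3)[C@]2(C)C(=O)C=C[C@@]12O`: 6300 nM
compound 2 `C[C@H]1CC[C@@H]2[C@@H](OC(=O)[C@]23CC(c2ccc(O)cc2)=NO3)[C@]2(C)C(=O)C=C[C@@]12O`: 20000 nM
compound 3 `C[C@H]1CC[C@@H]2[C@@H](OC(=O)[C@]23CC(c2ccccc2[N+](=O)[O-])=NO3)[C@]2(C)C(=O)C=C[C@@]12O`: 37000 nM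

Compound 2, at 20000 nM, cannot be told apart from compound 3, while its number is clearly higher than that of compound 1, which means weaker inhibition. Compound 4 `C[C@H]1CC[C@@H]2[C@@H](OC(=O)[C@]23CC(c2ccccc2Cl)=NO3)[C@]2(C)C(=O)C=C[C@@]12O` has not been measured yet. It keeps the shared core but has 2-chlorophenyl in place of 4-hydroxyphenyl on a carbon with a double bond to nitrogen.

The closest guide is the change from 4-hydroxyphenyl to 2-nitrophenyl, which gave a 1.9-fold higher number from compound 2 to compound 3 (0.27 log units; within the scatter) and so stayed within the scatter. The two steps that start from 4-(dimethylamino)phenyl were larger, at a 3.2-fold higher number from compound 1 to compound 2 (0.50 log units; beyond the scatter) and a 5.9-fold higher number from compound 1 to compound 3 (0.77 log units; beyond the scatter), but compound 4 does not share that starting group. For the measured compounds named here, no compound with chlorine has been measured, so this guide is thin. In this assay no step beyond the scatter is therefore expected, only a possible slight rise. The expected step is a 1.3-fold higher number from compound 2 to compound 4 (0.10 log units; within the scatter) and it remains an estimate. Compound 4 is estimated at 25000 nM, with an expected range of 10000 nM to 60000 nM.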

Compound 4, half-maximal inhibitory concentration: 12000 nM
Estimate against measurement, compound 4: 2.1-fold (0.32 log units) above; low and high end bracket the measured number.
By their numbers in this assay, from the lowest: compounds 1, 4, 2 and 3 (each within the scatter of the next, the first and the last beyond it).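

In this assay, 2-chlorophenyl carries no hydrogen-bond donor or acceptor, unlike 4-hydroxyphenyl, yet a 1.7-fold lower number from compound 2 to compound 4 (0.22 log units; within the scatter) stays within the scatter, and so does a 1.9-fold higher number from compound 1 to compound 4 (0.28 log units; within the scatter); compound 4 therefore cannot be separated from either compound. The clearer news comes from the swap of chloro for nitro on an aromatic carbon: a 3.1-fold lower number from compound 3 to compound 4 (0.49 log units; beyond the scatter) lies beyond the scatter, showing that at this position a change in a single group on the phenyl ring can move the number, though only modestly. No measurement here explains this difference between chloro and nitro.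

The compounds shown do not separate the identity of a group from where it sits on the phenyl ring. As far as these compounds go, it also remains open how a carboxylic acid on that ring, or a longer chain in place of the ring, would behave.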